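A few compounds are considered here, and "the series" means these few. Any claim that something is new, unique, unknown or untested is made for them only; others in the source may bear on it.

Measured in a functional assay on HL-60 cells (Homo sapiens) for inhibition, read by MTT assay, with a stated time of 48 h, tested at 10 uM; on this read-out higher numbers stand for more inhibition of growth at the one concentration tested and lower numbers for less inhibition of growth:
- Compound 1 `CN1CC[C@H](c2c(O)cc(O)c3c(=O)cc(/C=C/c4cccc(Cl)c4)oc23)[C@H](O)C1`: 35%
- Compound 2 `CN1CC[C@H](c2c(O)cc(O)c3c(=O)cc(/C=C/c4ccccc4F)oc23)[C@H](O)C1`: 62%

Compound 2, at 62%, stands highest of the two measured compounds, with compound 1 beyond the scatter below it. Compound 3 `CN1CC[C@H](c2c(O)cc(O)c3c(=O)cc(/C=C/c4ccccc4Cl)oc23)[C@H](O)C1` differs from compound 2 by a single exchange, chloro in place of fluoro on an aromatic carbon, ortho to a large group. Among the measured compounds shown here, only one measured step bears on this, a number 27 percentage points higher from compound 1 to compound 2 (beyond the scatter), and it bears only in part. That modest step changes both the halogen and the aromatic carbon carrying it, so the two changes cannot be separated. Compound 3 carries the halogen of compound 1, but at the place the halogen occupies in compound 2. For the measured compounds named here, no measured pair compares fluoro and chloro at that place. In this assay, a smaller step than the measured one is therefore expected, slightly downward and probably within the scatter. The estimated change is a number 7 percentage points lower from compound 2 to compound 3 (within the scatter). For compound 3 the expected value is 55%, with an estimated range of 36% to 72%.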

Compound 3, percent growth inhibition at one concentration: 61%
The estimate for compound 3 lay 6 percentage points below the measured number; low and high end bracket the measured number.
By their numbers in this assay, from the lowest: compound 1; then compounds 3 and 2 (each within the scatter of the next).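

In this assay, the exchange of chloro for fluoro on an aromatic carbon, ortho to a large group, gives a number 1 percentage points lower from compound 2 to compound 3 (within the scatter), so at this place the read-out does not tell the two halogens apart. The change to 2-chlorophenyl from 3-chlorophenyl keeps the halogen and alters only where it sits, giving a number 26 percentage points higher from compound 1 to compound 3 (beyond the scatter), and this separates the two changes joined in the earlier step, a number 27 percentage points higher from compound 1 to compound 2 (beyond the scatter): among these three compounds, the place of the halogen on the ring, not the choice of halogen, goes with the difference beyond the scatter. Nothing available explains why the number depends on this place.

The compounds shown leave open whether fluoro at the place chloro holds in compound 1 would give a number as low as that compound's, so the link between place and number rests on chloro alone. They also leave open whether the ortho place tolerates only halogens, or whether a methoxy group, an amine or a carboxylic acid there would keep the number of compound 2 and compound 3.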